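The source may report more compounds than this note shows. Statements on the series, on what has been measured and on what is new or still open speak of the compounds shown alone.

In a functional assay on NCI-H1993 cells (Homo sapiens) for inhibition, read by CCK-8 assay, with a stated time of 72 h (on this read-out higher numbers stand for weaker inhibition and lower numbers for stronger inhibition), three compounds have been measured so far. Compound 1 `c1cnc2ccc(Cn3cnc4ncc(-c5cn[nH]c5)nc43)cc2c1` gives 2890 nM. Compound 2 `OCCn1cc(-c2cnc3ncn(Cc4ccc5ncccc5c4)c3n2)cn1` differs from compound 1 in a single place, (2-hydroxyethyl in place of hydrogen on an aromatic nitrogen), and in this assay compound 2 gives 2330 nM. The step of a 1.2-fold lower number from compound 1 to compound 2 (0.09 log units; within the scatter) is small, so the two numbers cannot be told apart by this kind of measurement.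

Compound 3 `CC(NC/N=C/c1cn[nH]c1)c1ccc2ncccc2c1` is built on a different core; how the two cores differ is not broken down here. In this assay compound 3 gives 519 nM, the lowest of the three numbers, and its distance from both compound 1 and compound 2 lies beyond the scatter, so compound 3 stands apart as the strongest inhibitor of the three.

Compound 4 `CC(NC/N=C/c1cnn(CCO)c1)c1ccc2ncccc2c1` has not yet been measured. Compared with compound 3 it carries 2-hydroxyethyl in place of hydrogen on an aromatic nitrogen, the same change that was made from compound 1 to compound 2, at a place described in exactly the same words. Because a 1.2-fold lower number from compound 1 to compound 2 (0.09 log units; within the scatter) stayed within the scatter, the expected step of a 1.2-fold lower number from compound 3 to compound 4 (0.06 log units; within the scatter) is also small, with the number for compound 4 expected to stay close to that of compound 3. The estimate for compound 4 in this assay is 450 nM, with the expected range running from 200 nM to 1100 nM.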

Compound 4, half-maximal inhibitory concentration: 148 nM
Beside the measured number, compound 4's estimate is 3.0-fold (0.48 log units) above it; measured number outside the range, below it.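

In this assay, putting 2-hydroxyethyl in place of hydrogen on the aromatic nitrogen gives a 3.5-fold lower number from compound 3 to compound 4 (0.54 log units; beyond the scatter), so on the core of compound 3 this change brings stronger inhibition. The same change therefore did not carry over from one core to the other with the same size, as the two steps differ by more than measurement scatter can readily explain: the same change on two cores in this assay, a 1.2-fold lower number (0.09 log units; within the scatter) from compound 1 to compound 2 and a 3.5-fold lower number (0.54 log units; beyond the scatter) from compound 3 to compound 4, 2.8-fold (0.45 log units) apart, beyond the scatter of two such steps This shows that the step seen on one core was a poor guide to the step on the other in this pair of cores, but it does not show why they differ, and two pairs are too few to give a rule for any further core.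

The compounds shown leave open whether the stronger inhibition on the core of compound 3 needs the hydroxyl group or only a chain on that nitrogen. A plain ethyl group, a longer chain ending in a hydroxyl, or a chain carrying an amine or a carboxylic acid, each made on both cores, would show which part of the group matters and whether the two cores keep responding differently.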